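Swapping the Allyl Arm for a Methylbenzyl Arm

This account rests on a few compounds, and the source may have more. Where it says the series, first, only, none or still open, it means among the compounds named here.

Measured so far in a functional assay on RAW264.7 cells (Mus musculus) for inhibition, read by Griess assay, with stated times of 2 h and 24 h; on this read-out lower numbers stand for stronger inhibition and higher numbers for weaker inhibition:
compound 1 `COc1ccc([C@@H]2CC(=O)c3c(O)cc(OCc4cn(C5CCCC5)nn4)cc3O2)cc1O` gives 10500 nM
compound 2 `COc1ccc([C@@H]2CC(=O)c3c(O)cc(OCc4cn(Cc5ccccc5F)nn4)cc3O2)cc1O` gives 7320 nM
compound 3 `C=CCn1cc(COc2cc(O)c3c(c2)O[C@H](c2ccc(OC)c(O)c2)CC3=O)nn1` gives 13800 nM

All three share one core and differ only in the group on the aromatic nitrogen. Compound 3 is set apart from its neighbours by a 1.3-fold higher number from compound 1 to compound 3 (0.12 log units; within the scatter) and by a 1.9-fold higher number from compound 2 to compound 3 (0.28 log units; within the scatter), and both steps sit within the scatter, so the three numbers cannot be told apart with confidence.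

Compound 4 `COc1ccc([C@@H]2CC(=O)c3c(O)cc(OCc4cn(Cc5ccc(C)cc5)nn4)cc3O2)cc1O` has not yet been measured. Compared with compound 3 the change is 4-methylphenyl in place of vinyl on a saturated chain carbon bound to an aromatic nitrogen. The step that bears on it most directly is the one in the other direction, a 1.9-fold higher number from compound 2 to compound 3 (0.28 log units; within the scatter), where a 2-fluorophenyl gave way to vinyl at the same place; a 1.4-fold lower number from compound 1 to compound 2 (0.16 log units; within the scatter) also touches this group. Both steps were small, so for compound 4 a modest move toward a lower number in this assay is expected, not beyond the scatter. The estimated step is a 1.7-fold lower number from compound 3 to compound 4 (0.24 log units; within the scatter). Compound 4 is therefore expected to give about 8000 nM, with a likely range from 4000 nM to 16000 nM.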

Compound 4, half-maximal inhibitory concentration: 16800 nM
The estimate for compound 4 lay 2.1-fold (0.32 log units) below the measured number, outside the stated range (above it).
By their numbers in this assay, from the lowest: compounds 2, 1, 3 and 4 (each within the scatter of the next, the first and the last beyond it).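

In this assay, putting 4-methylbenzyl where allyl stood changes almost nothing: a 1.2-fold higher number from compound 3 to compound 4 (0.09 log units; within the scatter), and the comparison with cyclopentyl, a 1.6-fold higher number from compound 1 to compound 4 (0.20 log units; within the scatter), also stays within the scatter. The added aromatic ring therefore gives no clear gain over either non-benzyl group at this place. The new information lies between the two benzyl arms, where a 2.3-fold higher number from compound 2 to compound 4 (0.36 log units; beyond the scatter), a modest step but the first here to pass the scatter, so having a benzyl arm does not by itself set the number.

No measurement here explains that difference. On these data alone, the 2-fluorobenzyl and 4-methylbenzyl arms differ in both the ring's added group and its location, so 2-methylbenzyl and 4-fluorobenzyl would be needed to separate the two, and how an amine-bearing arm would behave remains open.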